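This account rests on a few compounds, and the source may have more. Where it says the series, first, only, none or still open, it means among the compounds named here.

Measured so far:
compound 1 `N#CC1=C(N)N(c2ccc(S(N)(=O)=O)cc2)C2=C(C(=O)CCC2)C1c1ccc(Cl)cc1Cl`: 50%
compound 2 `N#CC1=C(NC(=S)Nc2ccc(Cl)cc2)N(c2ccc(S(N)(=O)=O)cc2)C2=C(C(=O)CCC2)C1c1ccc(Cl)cc1Cl`: 60%

In a functional assay on Ehrlich cells (Mus musculus) for cytotoxicity, read by trypan blue exclusion, with a stated time of 2 h, tested at 25 ug/mL (on this read-out higher numbers stand for a stronger effect at the one concentration tested and lower numbers for a weaker effect), compound 1 gives 50%, and compound 2 gives 60%. For the measured compounds named here, compound 2 thus carries the higher of the two numbers, but the only step measured, a number 10 percentage points higher from compound 1 to compound 2 (within the scatter), lies within the scatter, so the two compounds cannot be told apart on this read-out.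

Compound 3 `N#CC1=C(NS(=O)(=O)c2ccc(Br)cc2)N(c2ccc(S(N)(=O)=O)cc2)C2=C(C(=O)CCC2)C1c1ccc(Cl)cc1Cl` has not yet been measured. It differs from compound 2 in one place: a group of 10 heavy atoms (6 carbon, 2 oxygen, 1 sulfur, 1 bromine; one six-membered aromatic ring of carbon only) in place of a group of 10 heavy atoms (7 carbon, 1 nitrogen, 1 sulfur, 1 chlorine; one six-membered aromatic ring of carbon only), on an amine nitrogen. The measured step from compound 1 to compound 2 concerns the same amine nitrogen, where a hydrogen atom gave way to the group that now leaves, and that step stayed within the scatter. Going by the values given here, no measured step covers the exchange of one such group for another, so the (4-bromophenyl)sulfonyl group is a new feature without a direct precedent here. Among the compounds with values here, with the only related step being small, the expectation in this assay is for no step beyond the scatter, so a number 5 percentage points lower from compound 2 to compound 3 (within the scatter) is estimated to be small. Compound 3 is therefore expected to give about 55%, within a range from 35% to 75%.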

Compound 3, a percentage reported as activity, at one concentration (the size of the read-out at that concentration, not a potency): 90%
Compound 3: the middle estimate sits 35 percentage points below what was measured, and the stated range ends below it.
By their numbers in this assay, from the lowest: compounds 1 and 2 (each within the scatter of the next); then compound 3.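

In this assay, for the compounds shown here, (4-bromophenyl)sulfonyl in place of hydrogen on the amine nitrogen gives a number 40 percentage points higher from compound 1 to compound 3 (beyond the scatter) and so shows that this nitrogen, which looked unresponsive after the one earlier step, can carry a group that clearly changes the read-out. Exchanging the group on this nitrogen for another with the same heavy-atom count and also one six-membered aromatic ring gives a number 30 percentage points higher from compound 2 to compound 3 (beyond the scatter) in this assay and so shows that those shared counts do not settle the outcome, since the atoms making up the group matter here. Nothing available explains the difference between these groups.

The sulfonyl part and the bromine enter together, so the compounds shown leave open which of them goes with the higher number, a question that a plain phenylsulfonyl group or a methylsulfonyl group on the same nitrogen would address. Also open, from the compounds shown here alone, is whether these steps hold at other concentrations, as the read-out gives the size of an effect at one concentration and not a potency.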